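A few compounds are considered here, and "the series" means these few. Any claim that something is new, unique, unknown or untested is made for them only; others in the source may bear on it.

In an ADME assay on microsomes (Rattus norvegicus) for metabolic stability (a higher number here means that the compound lasts longer, a lower number that the compound disappears faster), three compounds have been measured. Compound 1 `O=C(C1CCCC1)N1N=CCC1c1ccccc1` gives 0.2 h, compound 3 `C[C@@H]1C=NN(C(=O)C(C)(C)C)[C@@H]1c1ccccc1` gives 0.2 h, and compound 2 `CC(C)C(=O)N1N=CCC1c1ccccc1` holds the highest of the three numbers at 1.33 h. Compound 4 `CC(C)(CO)C(=O)N1N=CCC1c1ccccc1` differs from compound 2 by hydroxymethyl in place of hydrogen on a saturated chain carbon bound to a carbonyl carbon and two saturated chain carbons, turning isopropyl into 1-(hydroxymethyl)-1-methylethyl. Among the measured compounds shown here, the only measured step at a group on this carbonyl carbon is a 6.7-fold higher number from compound 1 to compound 2 (0.82 log units; beyond the scatter), which is modest but beyond the scatter. That step exchanges different groups and gives no direction for this change. Compound 3 differs from compound 2 in more than one place, so it settles nothing either. The expected step is a 1.3-fold lower number from compound 2 to compound 4 (0.12 log units; within the scatter), with no shift beyond the scatter anticipated. Compound 4 is estimated at 1 h, with an expected range from 0.35 h to 3 h.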

Compound 4, half-life: 0.917 h
For compound 4 the middle estimate is 1.1-fold (0.04 log units) above the measured one; the measured number falls inside the stated range.
By their numbers in this assay, from the lowest: compounds 1 and 3 (each within the scatter of the next); then compounds 4 and 2 (each within the scatter of the next).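

In this assay, hydroxymethyl in place of hydrogen on this saturated chain carbon gives a 1.5-fold lower number from compound 2 to compound 4 (0.16 log units; within the scatter), so the added group leaves the number within the scatter of the parent. Exchanging cyclopentyl for 1-(hydroxymethyl)-1-methylethyl on the carbonyl carbon gives a 4.6-fold higher number from compound 1 to compound 4 (0.66 log units; beyond the scatter), the same direction as the listed step to isopropyl. Nothing available explains either step. Still open, going by these compounds, is whether a carboxylic acid, an amine or a longer chain in place of hydroxymethyl would also stay within the scatter of compound 2.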